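From iodo to ethoxy: one more step in growth inhibition

A few compounds are considered here, and "the series" means these few. Any claim that something is new, unique, unknown or untested is made for them only; others in the source may bear on it.

In a functional assay on MDA-MB-468 cells (Homo sapiens) for antiproliferative activity (a higher number here means a weaker inhibitor of growth, a lower number a stronger inhibitor of growth), compound 1 `COc1ccc(-c2nc3cc(F)ccc3s2)cc1` gives 330 nM. Compound 2 `COc1ccc(-c2nc3cc(F)ccc3s2)cc1C`, with methyl in place of hydrogen on an aromatic carbon, gives 58 nM, and compound 3 `COc1ccc(-c2nc3cc(F)ccc3s2)cc1I`, with iodo on that carbon, gives 360 nM. The data show a 1.1-fold higher number from compound 1 to compound 3 (0.04 log units; within the scatter), so compound 3 sits level with the unsubstituted compound. They also show a 6.2-fold higher number from compound 2 to compound 3 (0.79 log units; beyond the scatter), which leaves it clearly behind the methyl compound.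

Compound 4 `CCOc1cc(-c2nc3cc(F)ccc3s2)ccc1OC` carries ethoxy in place of iodo on this aromatic carbon, ortho to a methoxy group: ethoxy in place of iodo on an aromatic carbon. Among the measured compounds shown here, no ethoxy compound has been measured, so the guidance is thin. For the measured compounds named here, two measured steps bear on the change. Adding iodo gave a 1.1-fold higher number from compound 1 to compound 3 (0.04 log units; within the scatter), whereas adding methyl gave a 5.7-fold lower number from compound 1 to compound 2 (0.76 log units; beyond the scatter), so a group on this carbon may lower the number but need not. Ethoxy holds carbon, as methyl does, so the expectation leans towards compound 2 at 58 nM, though this is a weak argument. The estimated change is a 7.2-fold lower number from compound 3 to compound 4 (0.86 log units; beyond the scatter), a modest lowering in this assay. For compound 4 the expected value is 50 nM, with an estimated range from 5 nM to 300 nM.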

Compound 4, concentration for 50% growth inhibition: 92 nM
For compound 4 the middle estimate is 1.8-fold (0.26 log units) below the measured one, and the stated range covers the measured number.
By their numbers in this assay, from the lowest: compounds 2 and 4 (each within the scatter of the next); then compounds 1 and 3 (each within the scatter of the next).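

In this assay, a carbon-and-oxygen group on this aromatic carbon, ortho to a methoxy group, goes with a clearly lower number than either hydrogen (a 3.6-fold lower number from compound 1 to compound 4 (0.55 log units; beyond the scatter)) or iodo (a 3.9-fold lower number from compound 3 to compound 4 (0.59 log units; beyond the scatter)). Ethoxy and methyl cannot be told apart here (a 1.6-fold higher number from compound 2 to compound 4 (0.20 log units; within the scatter)), a step within the scatter, so two different groups now give a similar gain over hydrogen, while iodo goes against that pattern and stays level with hydrogen. Ethoxy brings a hydrogen-bond acceptor that iodo lacks, but no measurement here explains the gap between these groups.

The compounds shown leave open whether a longer chain such as propoxy, or an amine or a hydroxyl group on this carbon, would keep the number as low as methyl and ethoxy do. They also leave open whether the same ranking of groups would hold on a core without the fluoro group or with something other than methoxy ortho to the changing group.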